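This account rests on a few compounds, and the source may have more. Where it says the series, first, only, none or still open, it means among the compounds named here.

Measured in a functional assay on CCRF-CEM cells (Homo sapiens) for inhibition; on this read-out lower numbers stand for stronger inhibition and higher numbers for weaker inhibition:
- compound 1 `O=C1/C(=C/c2ccc(F)cc2)CCc2ccccc21`: 33400 nM
- compound 2 `Cc1ccc(/C=C2\CCc3ccccc3C2=O)cc1`: 460000 nM

Of these two numbers, compound 2 holds the higher, at 460000 nM, and is thus the weaker inhibitor. Next is compound 3 `CN(C)c1ccc(/C=C2\CCc3ccccc3C2=O)cc1`, which differs from compound 2 as follows: dimethylamino in place of methyl on an aromatic carbon. This puts dimethylamino in place of methyl on an aromatic carbon, para to a large group.

For the measured compounds named here, one measured step bears on this change: a 14-fold higher number from compound 1 to compound 2 (1.14 log units; beyond the scatter). Going by the values given here, that large step also came from a substituent exchange on this carbon, but no measured compound carries dimethylamino, so the direction remains uncertain. With compound 2 at the high end at 460000 nM, a moderate move towards a lower number is expected in this assay. The expected change is a 4.6-fold lower number from compound 2 to compound 3 (0.66 log units; beyond the scatter). For compound 3 the estimated value is 100000 nM, with an expected range of 20000 nM to 450000 nM.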

Compound 3, half-maximal inhibitory concentration: 1650 nM
Compound 3: middle estimate off by 61-fold (1.78 log units), on the high side; the measured number lies below the stated range.
By their numbers in this assay, from the lowest: compound 3; then compound 1; then compound 2.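

In this assay this aromatic carbon proves far more sensitive than the first pair could show, with dimethylamino in place of methyl giving a 280-fold lower number from compound 2 to compound 3 (2.45 log units; beyond the scatter) and dimethylamino in place of fluoro giving a 20-fold lower number from compound 1 to compound 3 (1.31 log units; beyond the scatter). Both steps are large and run the same way, making compound 3 the strongest inhibitor of the three, so the substituent here can do more than weaken inhibition from the level of compound 1. No measured information on the series accounts for the size of these steps.

From the compounds shown here alone, whether the gain is particular to dimethylamino or extends to a primary amine, a diethylamino group, a pyrrolidine or a morpholine remains open. Also open, going by these compounds, is how a methoxy group compares on this carbon, and whether dimethylamino would keep its effect on another carbon of the ring.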